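Ring size of the amine-bearing linker on the pyrazole nitrogen

A few compounds are considered here, and "the series" means these few. Any claim that something is new, unique, unknown or untested is made for them only; others in the source may bear on it.

Compound 1, `NCCCCn1cc(-c2ccc3cc[nH]c3c2)c(C(F)(F)F)n1`: 330 nM
Compound 2, `NC[C@H]1C[C@H](n2cc(-c3ccc4cc[nH]c4c3)c(C(F)(F)F)n2)C1`: 170 nM

Of the compounds shown here, two have been measured in an assay on isolated protein for inhibition of Myeloperoxidase (Homo sapiens); on this read-out lower numbers stand for stronger inhibition and higher numbers for weaker inhibition. Compound 1 `NCCCCn1cc(-c2ccc3cc[nH]c3c2)c(C(F)(F)F)n1` gives 330 nM, and compound 2 `NC[C@H]1C[C@H](n2cc(-c3ccc4cc[nH]c4c3)c(C(F)(F)F)n2)C1` gives 170 nM. Among the measured compounds shown here, the only step between them, a 1.9-fold lower number from compound 1 to compound 2 (0.29 log units; within the scatter), stays within the scatter, so the two numbers cannot be told apart, and compound 2 has no distinct standing against compound 1 on the evidence so far.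

Compound 3 `N[C@@H]1CC[C@@H](n2cc(-c3ccc4cc[nH]c4c3)c(C(F)(F)F)n2)C1` differs from compound 2 in one place: a group of 6 heavy atoms (5 carbon, 1 nitrogen; one five-membered non-aromatic ring of carbon only) in place of a group of 6 heavy atoms (5 carbon, 1 nitrogen; one four-membered non-aromatic ring of carbon only), on an aromatic nitrogen. For the measured compounds named here, the one measured step bears on this change only loosely, since it swapped an open chain for a four-membered ring rather than one ring for another; that step was within the scatter. Going by the values given here, with no comparison of a four-membered ring against a five-membered ring at this position, the expectation rests on the small size of the one step seen, and compound 3 is expected to come out close to compound 2, with a step of a 1.2-fold higher number from compound 2 to compound 3 (0.07 log units; within the scatter) in this assay. The estimate for compound 3 is 200 nM, within a range from 70 nM to 600 nM.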

Compound 3, half-maximal inhibitory concentration: 70 nM
Compound 3: the middle estimate sits 2.9-fold (0.46 log units) above what was measured; measured number inside the range.
By their numbers in this assay, from the lowest: compound 3; then compounds 2 and 1 (each within the scatter of the next).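

Among the compounds shown here, replacing the four-membered ring with the five-membered ring on the aromatic nitrogen gave a 2.4-fold lower number from compound 2 to compound 3 (0.39 log units; beyond the scatter) in this assay, the first step in this short series to clear the scatter. It shows that this position can separate two groups with the same atoms and the same count of hydrogen-bond donors and acceptors, which the earlier pair of compounds could not show. Against the open chain, the five-membered ring gave a 4.7-fold lower number from compound 1 to compound 3 (0.67 log units; beyond the scatter), so one ring-bearing group now stands apart from the chain, whereas the step from the chain to the four-membered ring of compound 2 did not; nothing available here explains the difference between the two rings.

The compounds shown leave open whether a six-membered ring of carbon only would continue or reverse this direction, and whether ring size alone accounts for the step, as the two groups are joined differently in more than their ring. They also leave open how the other arrangements at the two defined stereocentres of the five-membered ring would compare, and whether a hydroxyl group could stand in for the amine.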